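From nitro to bromo on a shared core

The source may report more compounds than this note shows. Statements on the series, on what has been measured and on what is new or still open speak of the compounds shown alone.

Compound 1 `CC(C)n1c(/C=C2/C(=O)Nc3ccccc32)nc2ccccc21`: 38100 nM
Compound 2 `CCn1c(/C=C2/C(=O)Nc3ccc(C)cc32)nc2ccccc21`: 39300 nM
Compound 3 `Cn1c(/C=C2/C(=O)Nc3ccc([N+](=O)[O-])cc32)nc2ccccc21`: > 50000 nM

All three compounds were tested in a functional assay on DU-145 cells (Homo sapiens) for cytotoxicity, read by MTT assay, with a stated time of 48 h; on this read-out lower numbers stand for stronger inhibition and higher numbers for weaker inhibition. In this test, compound 1 gives 38100 nM and compound 2 gives 39300 nM, and these two values lie close together.

For compound 3, the assay reports only a limit, > 50000 nM. On these data alone, it is therefore not an exact number, and the true position of compound 3 remains open.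

The next compound is compound 4 `Cn1c(/C=C2/C(=O)Nc3ccc(Br)cc32)nc2ccccc21`. It carries bromo in place of nitro on an aromatic carbon. That carbon belongs to a six-membered aromatic ring of carbon only, part of a fused or bridged system of two rings.

Within the data shown here, no measured pair of compounds shows what this swap does on its own, so any forecast is rough. Among the measured compounds shown here, the only exact numbers nearby are those of compound 1 at 38100 nM and compound 2 at 39300 nM, and they suggest a weak result for compound 4 as well.

The expected step of an at least 1.4-fold lower number from compound 3 to compound 4 (0.15 log units; that floor lies within the scatter) is small, and no move beyond the usual scatter is expected. For compound 4 the estimated value is 35000 nM, with an expected range of 15000 nM to 50000 nM.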

Compound 4, half-maximal inhibitory concentration: 39600 nM
Estimate against measurement, compound 4: 1.1-fold (0.05 log units) below; low and high end bracket the measured number.
By their numbers in this assay, from the lowest: compounds 1, 2 and 4 (each within the scatter of the next). At a limit, above all of these: compound 3.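

Among these compounds, putting bromo in place of nitro on this aromatic carbon gives an at least 1.2-fold lower number from compound 3 to compound 4 (0.10 log units; that floor lies within the scatter), the only step so far that can be read at all. In this assay, compound 4 gives 39600 nM, so with bromo this position now carries an exact number. Among the compounds shown here, the only compound that differs from compound 4 in one place is compound 3. For compound 3, > 50000 nM is a limit and not a number, so the step has a floor but no known size, and since that floor lies within the scatter, it does not show that bromo truly lowers the number compared with nitro: the limit of > 50000 nM in this assay, at which 1 of the 4 values shown sits.

On these data alone, how far apart compound 3 and compound 4 really lie stays open, and so does whether this swap does anything beyond the scatter. As far as these compounds go, it also remains open how the same aromatic carbon on the core of compound 4 would respond to a different group, such as an amine, a methoxy group or a carboxylic acid, and whether any of these would bring a clearly lower number in this assay.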